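A Chloro Substituent Added to the Only Measured Compound

The source may report more compounds than this note shows. Statements on the series, on what has been measured and on what is new or still open speak of the compounds shown alone.

Among the measured compounds shown here, compound 1 `CC(=O)N1N=C(Nc2nc3ccc(C)cc3s2)CC1c1ccccc1` is the only member of this set for which a number exists. In a functional assay on the whole organism (strain albino) with Mus musculus as the target, with a stated time of 0.5 h (a higher number here means that more compound is needed for the effect, a lower number that less compound is needed), compound 1 gives 112 umol/kg. Compound 2 `CC(=O)N1N=C(Nc2nc3ccc(Cl)cc3s2)CC1c1ccccc1` was entered in this assay without a result, recorded as "not determined" (no result reported), and compound 3 `CC(=O)N1N=C(Nc2nc3ccccc3s2)CC1c1ccccc1` likewise stands at "not determined" (no result reported) there. For the measured compounds named here, no two measured compounds differ in a single place, so no measured step can be drawn from these data. Compound 4 `CC(=O)N1N=C(Nc2nc3ccc(C)cc3s2)CC1c1ccc(Cl)cc1` differs from compound 1 by chloro in place of hydrogen on an aromatic carbon. Since no comparable change has been measured here, a 1.0-fold lower number from compound 1 to compound 4 (0.01 log units; within the scatter) is expected to remain within the usual scatter, in no firm direction. Compound 4 is expected to give 110 umol/kg in this assay, with a range from 45 umol/kg to 280 umol/kg.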

Compound 4, dose for half-maximal effect: 27.5 umol/kg
The estimate for compound 4 lay 4.0-fold (0.60 log units) above the measured number; measured number outside the range, below it.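

Among the compounds shown here, the change from phenyl to 4-chlorophenyl gives a 4.1-fold lower number from compound 1 to compound 4 (0.61 log units; beyond the scatter) in this assay, the first readable step in this set. It shows that the number responds to a substituent at this place, para to a large group on the aromatic ring, although this rests on one pair of compounds. No available evidence accounts for the shift. Whether the response is specific to chloro remains open, as the compounds shown do not include a methoxy group or an amine at this place. As far as these compounds go, whether a larger halogen such as bromo would give a similar step also remains open.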